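This account rests on a few compounds, and the source may have more. Where it says the series, first, only, none or still open, it means among the compounds named here.

In a toxicity assay on cells (Erythrocyte, Mus musculus) for activation, read by spectrophotometry and hemolysis, with a stated time of 30 min (on this read-out higher numbers stand for an effect only at larger amounts of compound and lower numbers for an effect already at smaller amounts), three compounds built on one shared core have been measured so far. Compound 1 `COc1cc(/C=N/Nc2nc3ccccc3s2)ccc1O` gives > 200 ug/mL, which is a limit of the assay and not a number. Compound 2 `Oc1ccc(/C=N/Nc2nc3ccccc3s2)cc1O` gives > 200 ug/mL, again a limit. Compound 3 `Clc1ccc(/C=N/Nc2nc3ccccc3s2)cc1` gives > 200 ug/mL, also a limit. Within the data shown here, the series so far therefore rests on one reading: the limit of > 200 ug/mL in this assay, at which 3 of the 3 values shown sit. Compound 3 thus has no exact number from which to measure a step.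

Compound 4 `CN(C)c1ccc(/C=N/Nc2nc3ccccc3s2)cc1` keeps the core and changes one group on compound 3: dimethylamino in place of chloro on an aromatic carbon. Dimethylamino stands in place of chloro on an aromatic carbon, para to a large group. Among the measured compounds shown here, only one measured step is available, and it concerns a different change: a step that the two limits leave unreadable from compound 1 to compound 2. It offers no size to carry over, so no step beyond the scatter can be argued for in this assay, and none is expected. The expectation rests on compound 3, whose reading of > 200 ug/mL is a limit. Another limit is the likeliest report for compound 4. The expected change is a step that the limit leaves unreadable from compound 3 to compound 4. Compound 4 is estimated at 250 ug/mL, with an expected range from 100 ug/mL to 500 ug/mL.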

Compound 4, half-maximal effective concentration: > 200 ug/mL
Compound 4 gave a limit, no number; the forecaster's own chance of this, stated with the estimate: 85%; the middle value is on the limit's open side.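

No new step can be read: compound 3 and compound 4 both stand as limits and not numbers, so in this assay the change from chloro to dimethylamino has no readable size. The compounds shown leave open whether any change on the shared core gives a reading inside the measurable range, and the series so far offers only this: the limit of > 200 ug/mL in this assay, at which 4 of the 4 values shown sit.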